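Trifluoromethyl for fluoro, carried from one core to another

A few compounds are considered here, and "the series" means these few. Any claim that something is new, unique, unknown or untested is made for them only; others in the source may bear on it.

Compound 1 `CC(=O)Nc1ccc(O)c(C(=O)/C=C/c2cccc(F)c2)c1` and compound 2 `CC(=O)Nc1ccc(O)c(C(=O)/C=C/c2cccc(C(F)(F)F)c2)c1` share a core and differ in one place: trifluoromethyl in place of fluoro on an aromatic carbon. In an ADME assay on THP-1 cells (Homo sapiens) for cytotoxicity, read by flow cytometry and propidium iodide staining, with a stated time of 72 h (on this read-out lower numbers stand for stronger inhibition and higher numbers for weaker inhibition), compound 1 gives 78600 nM, and compound 2 gives 8400 nM. That is a 9.4-fold lower number from compound 1 to compound 2 (0.97 log units; beyond the scatter), a step that stands beyond the scatter.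

Compound 3 `CC(=O)Nc1ccc2oc(-c3cccc(F)c3)cc(=O)c2c1` rests on a different core, and the difference between the two cores is not broken down here. In this assay compound 3 reaches only a limit, > 125000 nM, and (the limit of > 125000 nM in this assay, at which 1 of the 3 values shown sits).

Compound 4 `CC(=O)Nc1ccc2oc(-c3cccc(C(F)(F)F)c3)cc(=O)c2c1` has not been measured. It stands to compound 3 as compound 2 stands to compound 1: trifluoromethyl in place of fluoro on an aromatic carbon. Since the place of the change is described in the same words for both pairs, it is the same change, made on a second core. The expectation for compound 4 in this assay rests on the earlier step of a 9.4-fold lower number from compound 1 to compound 2 (0.97 log units; beyond the scatter), with the added uncertainty that compound 3 gives only a limit. The estimated step is an at least 2.0-fold lower number from compound 3 to compound 4 (0.31 log units; beyond the scatter). Compound 4 is thus expected to give about 60000 nM, within 15000 nM to 250000 nM.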

Compound 4, half-maximal inhibitory concentration: 50000 nM
Estimate against measurement, compound 4: 1.2-fold (0.08 log units) above; low and high end bracket the measured number.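

In this assay, trifluoromethyl in place of fluoro again goes with a lower number on the second core, an at least 2.5-fold lower number from compound 3 to compound 4 (0.39 log units; beyond the scatter), so the direction of the change carries over from one core to the other. Going by these compounds, compound 3 reaches only a limit of the assay, > 125000 nM, so the true size of this second step remains unknown, and only its smallest size can be stated: the limit of > 125000 nM in this assay, at which 1 of the 4 values shown sits. The result thus shows the same direction on both cores among these four compounds, but it does not show that the change has the same size on each, nor that it would hold on any further core: the same change on two cores in this assay, a 9.4-fold lower number (0.97 log units; beyond the scatter) from compound 1 to compound 2 and an at least 2.5-fold lower number (0.39 log units; beyond the scatter) from compound 3 to compound 4; the limit leaves it open whether they differ.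

The compounds shown leave open whether other groups at that place on the aromatic ring, such as chloro, methoxy or a nitrile, would follow fluoro and trifluoromethyl on either core. They also leave open how an amine or a carboxylic acid there would read in this assay.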